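Bromo in Place of Hydrogen on an Inactive Pair

A few compounds are considered here, and "the series" means these few. Any claim that something is new, unique, unknown or untested is made for them only; others in the source may bear on it.

Compound 1, `COc1ccc2[nH]c(=O)c(-c3nc4cc(F)ccc4[nH]3)cc2c1`: in a functional assay on SK-OV-3 cells (Homo sapiens) for cytotoxicity, read by MTT assay, with a stated time of 48 h (on this read-out lower numbers stand for stronger inhibition and higher numbers for weaker inhibition), compound 1 reaches only the assay limit of > 100000 nM.
Compound 2, `COc1ccc2[nH]c(=O)c(-c3nc4ccccc4[nH]3)cc2c1`: in this assay compound 2 likewise reaches only the assay limit of > 100000 nM.

For the measured compounds named here, compound 2 therefore stands at the limit, with no number of its own; the same holds for the only other value shown, as the limit of > 100000 nM in this assay, at which 2 of the 2 values shown sit, records. Going by the values given here, the one measured step, a step that the two limits leave unreadable from compound 1 to compound 2, is left unreadable by those two limits, so it gives no size and no direction.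

Compound 3, `COc1ccc2[nH]c(=O)c(-c3nc4cc(Br)ccc4[nH]3)cc2c1`, differs from compound 2 by bromo in place of hydrogen on an aromatic carbon. Among the compounds with values here, the only measured step that bears on this change is the unreadable one, so no step of a readable size can be expected in this assay from this evidence. The expected step of a number no higher from compound 2 to compound 3 (the limit leaves the size open) is best treated as none beyond the scatter. Compound 3 is thus estimated at 100000 nM, within 30000 nM to 300000 nM, most likely reported again as a limit.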

Compound 3, half-maximal inhibitory concentration: > 100000 nM
Compound 3: no number, only a limit; the forecaster's own chance of this, stated with the estimate: 80%; the middle value lies on the limit itself.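

Compound 3 also reaches only a limit, so the steps among compound 1, compound 2 and compound 3 cannot be read: the limit of > 100000 nM in this assay, at which 3 of the 3 values shown sit.

The compounds shown leave open whether fluoro, hydrogen or bromo on this aromatic carbon makes any difference in this assay.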